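Isopropyl in place of aminobutyl on the shared core

This account rests on a few compounds, and the source may have more. Where it says the series, first, only, none or still open, it means among the compounds named here.

The series rests on a shared core, seen in compound 1 `Cc1ncc([N+](=O)[O-])n1CCOC(=O)c1cc(NC(=O)C(C)NC(=O)OCc2ccccc2)ccc1O`, that carries an ester-linked nitroimidazole side arm and an amide whose chain carbon bears a carbamate-protected amine. In a functional assay on the whole organism (strain Wistar) for inhibition, with Rattus norvegicus as the target, read by paw edema, with stated times of 1 h and 24 h, at a dose of 10 mg/kg by the intraperitoneal route (on this read-out higher numbers stand for more inhibition at the one dose given (going by the name of the read-out) and lower numbers for less inhibition), compound 1 gives 0%. Compound 2 `Cc1ncc([N+](=O)[O-])n1CCOC(=O)c1cc(NC(=O)[C@H](C)NC(=O)OCc2ccccc2)ccc1O` has the same atoms and bonds, and in this assay compound 2 gives 11.6%; the step of a number 11.6 percentage points higher from compound 1 to compound 2 (beyond the scatter) rests only on the fact that (the fact that one of compounds 1 and 2 is drawn with a defined configuration and the other without, at the place where they differ). Compound 3 `Cc1ncc([N+](=O)[O-])n1CCOC(=O)c1cc(NC(=O)[C@H](CCCCN)NC(=O)OCc2ccccc2)ccc1O` extends the chain carbon further, and in this assay compound 3 gives 23.4%, the highest of the three numbers, with the step of a number 11.8 percentage points higher from compound 2 to compound 3 (beyond the scatter).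

Compound 4 `Cc1ncc([N+](=O)[O-])n1CCOC(=O)c1cc(NC(=O)[C@@H](NC(=O)OCc2ccccc2)C(C)C)ccc1O` moves the other way: isopropyl in place of 4-aminobutyl on a saturated chain carbon bound to an amide-type nitrogen and a carbonyl carbon. Within the data shown here, the one measured step that bears on this place, a number 11.8 percentage points higher from compound 2 to compound 3 (beyond the scatter), shows that adding an amine-bearing chain at this carbon raised inhibition by a modest amount. Compound 4 removes that chain entirely and puts a short branched group in its stead, so a modest fall is expected, roughly undoing that gain: an estimated step of a number 11.4 percentage points lower from compound 3 to compound 4 (beyond the scatter). Compound 4 is thus expected to give about 12% in this assay, within a range from 0% to 25%.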

Compound 4, a percentage reported as inhibition, in the whole organism at one dose (the size of the read-out at that dose, not a potency): 51.7%
The estimate for compound 4 lay 39.7 percentage points below the measured number; the whole stated range lies below it.
By their numbers in this assay, from the lowest: compound 1; then compound 2; then compound 3; then compound 4.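

In this assay, the step for isopropyl in place of 4-aminobutyl on a saturated chain carbon bound to an amide-type nitrogen and a carbonyl carbon is a number 28.3 percentage points higher from compound 3 to compound 4 (beyond the scatter), so among these compounds the highest number at this place comes with a group that carries no nitrogen and has no hydrogen-bond donor. Measured against the methyl of compound 2, the same group gives a number 40.1 percentage points higher from compound 2 to compound 4 (beyond the scatter), and this large step shows that the change at this carbon can outweigh the modest gain seen earlier with the amine-bearing chain; the number also does not simply follow the length of the group, as compound 3, with the longest chain here, stands below compound 4. Nothing in the evidence at hand bears on why isopropyl stands above both methyl and 4-aminobutyl at this place.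

The compounds shown leave open whether a plain butyl chain without its amine, or a chain ending in a carboxylic acid, would stand nearer compound 3 or compound 4. They also leave open whether a larger branched group such as tert-butyl or a benzyl group would go beyond isopropyl or fall back.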